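This account rests on a few compounds, and the source may have more. Where it says the series, first, only, none or still open, it means among the compounds named here.

Measured in a functional assay (Cavia porcellus) with Rattus norvegicus as the target; on this read-out lower numbers stand for an effect already at smaller amounts and higher numbers for an effect only at larger amounts of compound:

- compound 1 `CC1=CSC(OCC(C)C)(c2ccc(Br)cc2)c2noc(=O)n21` gives 310 nM
- compound 2 `CCCCOC1(c2ccc(Br)cc2)SC=C(C)n2c1noc2=O` gives 1020 nM
- compound 3 `CC1=CSC(OC(C)C)(c2ccc(Br)cc2)c2noc(=O)n21` gives 270 nM

Compound 3 shares the low end of the series, as the data show a 1.1-fold lower number from compound 1 to compound 3 (0.06 log units; within the scatter) and also a 3.8-fold lower number from compound 2 to compound 3 (0.58 log units; beyond the scatter) on this read-out.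

Compound 4 `CC1=CSC(OCc2ccccc2)(c2ccc(Br)cc2)c2noc(=O)n21` has benzyl in place of isopropyl on an oxygen on a saturated carbon.

Within the data shown here, no measured compound carries a ring on that oxygen, so the guide is weak. The steps on that oxygen run from within the scatter to modest, the largest being a 3.8-fold lower number from compound 2 to compound 3 (0.58 log units; beyond the scatter) and a 3.3-fold higher number from compound 1 to compound 2 (0.52 log units; beyond the scatter) for the butyl of compound 2. A modest rise is therefore expected in this assay, with an estimated 2.0-fold higher number from compound 3 to compound 4 (0.31 log units; beyond the scatter) as the working figure. For compound 4 the estimate is 550 nM, with an expected range of 180 nM to 1600 nM.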

Compound 4, half-maximal effective concentration: 590 nM
Compound 4: the middle estimate sits 1.1-fold (0.03 log units) below what was measured; low and high end bracket the measured number.
By their numbers in this assay, from the lowest: compounds 3, 1, 4 and 2 (each within the scatter of the next, the first and the last beyond it).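

In this assay the change from isopropoxy to benzyloxy brings the first ring onto that oxygen and gives only a 2.2-fold higher number from compound 3 to compound 4 (0.34 log units; beyond the scatter) on this read-out. Set against the open chains, the data show a 1.9-fold higher number from compound 1 to compound 4 (0.28 log units; within the scatter) and a 1.7-fold lower number from compound 2 to compound 4 (0.24 log units; within the scatter) so benzyl does not stand apart from isobutyl or butyl here. No supporting data bear on why the numbers fall this way.

Still open, going by these compounds, is whether a phenethyl group, with a longer chain before the ring, follows benzyl or butyl. Equally open, on these data alone, is what an amine or a carboxylic acid at the end of a chain on that oxygen would give.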